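Aryl and arylalkyl amides on a shared piperidine core

The source may hold more compounds than are shown below. What is called first, only, known or untested is meant among the compounds shown, and "the series" means these compounds.

Compound 1 `Cc1ccc(C(=O)N[C@@H](C(=O)N2CCC(c3ccc(Cl)cc3)CC2)C(C)C)cc1` gives 25 nM in an assay on THP-1 cells for displacement of a labelled ligand from C-C chemokine receptor type 1 (Homo sapiens); on this read-out higher numbers stand for weaker inhibition and lower numbers for stronger inhibition. Compound 2 `CC(C)[C@@H](NC(=O)NCc1ccccc1)C(=O)N1CCC(c2ccc(Cl)cc2)CC1` gives 180 nM in this assay, the step being a 7.2-fold higher number from compound 1 to compound 2 (0.86 log units; beyond the scatter). Compound 3 `Cc1cccc(CCC(=O)N[C@@H](C(=O)N2CCC(c3ccc(Cl)cc3)CC2)C(C)C)c1` gives 22 nM in this assay; this is the lowest of the three numbers, but the step from the aryl amide is only a 1.1-fold lower number from compound 1 to compound 3 (0.06 log units; within the scatter), while the step from the urea is an 8.2-fold lower number from compound 2 to compound 3 (0.91 log units; beyond the scatter).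

Compound 4 `CC(C)[C@@H](NC(=O)c1cc2ccccc2s1)C(=O)N1CCC(c2ccc(Cl)cc2)CC1` differs from compound 3 by 1-benzothiophen-2-yl in place of 2-(3-methylphenyl)ethyl on a carbonyl carbon. Within the data shown here, two measured steps bear on this. The swap between an aromatic ring set directly on the carbonyl carbon and a two-carbon-linked aromatic ring, a 1.1-fold lower number from compound 1 to compound 3 (0.06 log units; within the scatter), lies within the scatter. The swap to benzylamino, an 8.2-fold lower number from compound 2 to compound 3 (0.91 log units; beyond the scatter), is beyond the scatter, but compound 4 keeps a carbon group on the carbonyl carbon rather than a urea nitrogen. Compound 4 therefore resembles compound 1 in its attachment, and the step expected in this assay is a 1.1-fold higher number from compound 3 to compound 4 (0.06 log units; within the scatter), none beyond the scatter. Compound 4 is estimated to give 25 nM in this assay, with a range from 8 nM to 80 nM.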

Compound 4, half-maximal inhibitory concentration: 58 nM
The estimate for compound 4 lay 2.3-fold (0.37 log units) below the measured number; the range from low to high includes it.
By their numbers in this assay, from the lowest: compounds 3 and 1 (each within the scatter of the next); then compound 4; then compound 2.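

On the carbonyl carbon whose other neighbour is the amide-type nitrogen, the earlier carbon-attached groups, 4-methylphenyl and 2-(3-methylphenyl)ethyl, could not be told apart, whereas 1-benzothiophen-2-yl does separate from both (a 2.3-fold higher number from compound 1 to compound 4 (0.37 log units; beyond the scatter); a 2.6-fold higher number from compound 3 to compound 4 (0.42 log units; beyond the scatter)). A carbon attachment at this position therefore does not by itself keep the number at the level of the first two amides, and compound 4 is the case against that reading. Benzylamino remains the least favourable group shown (a 3.1-fold lower number from compound 2 to compound 4 (0.49 log units; beyond the scatter)), so the urea's disadvantage survives this new comparison.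

From the compounds shown here alone, whether the rise follows from the sulfur or from the second aromatic ring stays open; 1-benzofuran-2-yl or 2-naphthyl on the same carbonyl carbon would separate the two. Nothing available here accounts for the rise in the number.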